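The compounds below may be only part of what the source reports. "The series", "measured", "known", "first", "only" and "open" are said of these compounds alone.

Compound 1 `CCCCNS(=O)(=O)c1ccc(Nc2ncc3c(n2)N(C2CCCC2)[C@H](CC)C(=O)N3C)cc1` and compound 3 `CC[C@@H]1C(=O)N(C)c2cnc(Nc3ccc(S(N)(=O)=O)cc3)nc2N1C1CCCC1` share one core and differ only in hydrogen in place of butyl on a sulfonamide nitrogen. In a functional assay on A549 cells (Homo sapiens) for antiproliferative activity, read by CCK-8 assay, with a stated time of 72 h (a higher number here means a weaker inhibitor of growth, a lower number a stronger inhibitor of growth), compound 1 gives 477 nM, while compound 3 gives 3390 nM, so that a 7.1-fold higher number from compound 1 to compound 3 (0.85 log units; beyond the scatter). Compound 2 `CCCCNS(=O)(=O)c1ccc(Nc2ncc3c(n2)N(c2ccn(C)n2)C(CC)C(=O)N3C)cc1` is built on another core; the difference between the two cores is not broken down here. In this assay compound 2 gives 10600 nM, the highest of the three numbers. Compound 4 `CCC1C(=O)N(C)c2cnc(Nc3ccc(S(N)(=O)=O)cc3)nc2N1c1ccn(C)n1` has not yet been measured and stands to compound 2 as compound 3 stands to compound 1, carrying the same change, (hydrogen in place of butyl on a sulfonamide nitrogen). The step from compound 2 to compound 4 in this assay is expected to be a 5.7-fold higher number from compound 2 to compound 4 (0.75 log units; beyond the scatter) because the same change earlier gave a 7.1-fold higher number from compound 1 to compound 3 (0.85 log units; beyond the scatter). On this basis compound 4 is estimated at 60000 nM, within a range from 20000 nM to 180000 nM.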

Compound 4, concentration for 50% growth inhibition: "not active" (no number reported)
For compound 4 the study gives words and no number, so the estimate cannot be set against anything.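

Among these compounds, compound 4 is reported as "not active" in this assay, without a number, so no step from compound 2 to compound 4 can be read. Going by these compounds, whether replacing butyl with hydrogen acts alike on both cores stays open. Nothing measured here bears on this result.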